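Benzyloxy variant of the alkoxy series

The compounds below may be only part of what the source reports. "The series", "measured", "known", "first", "only" and "open" are said of these compounds alone.

In an assay on CHO cells for inhibition of sodium- and chloride-dependent glycine transporter 1 (Homo sapiens), read by scintillation counting (a higher number here means that more compound is needed for the effect, a lower number that less compound is needed), compound 1 `C[C@H](Oc1ccc(S(C)(=O)=O)cc1C(=O)N1Cc2cc(C(F)(F)F)cnc2C1)C(F)(F)F` gives 50 nM. Compound 2 `CC(C)Oc1ccc(S(C)(=O)=O)cc1C(=O)N1Cc2cc(C(F)(F)F)cnc2C1` gives 70 nM in this assay, and compound 3 `CS(=O)(=O)c1ccc(OCCC(F)(F)F)c(C(=O)N2Cc3cc(C(F)(F)F)cnc3C2)c1` gives 111 nM. On these three numbers compound 3 stands highest: its nearest neighbour is compound 2, within the scatter, while compound 1 lies beyond it. The steps that alter the group on the oxygen on the aromatic ring are a 1.4-fold higher number from compound 1 to compound 2 (0.15 log units; within the scatter), a 2.2-fold higher number from compound 1 to compound 3 (0.35 log units; beyond the scatter) and a 1.6-fold higher number from compound 2 to compound 3 (0.20 log units; within the scatter); all are small, and only one exceeds the scatter.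

Compound 4 `CS(=O)(=O)c1ccc(OCc2ccccc2)c(C(=O)N2Cc3cc(C(F)(F)F)cnc3C2)c1` is not yet measured in this assay. It differs from compound 3 by phenyl in place of 2,2,2-trifluoroethyl on a saturated chain carbon bound to an oxygen on an aromatic ring. The steps above bear on it only in that they exchange groups at the same oxygen, and none of them brings in an aromatic ring; the direction they show is a modest rise as the group moves away from that of compound 1, with compound 3 the highest so far. Within the data shown here, no measured step carries a phenyl, so the expectation rests on the smallness of the three known steps. For compound 4 the estimated step is a 1.4-fold higher number from compound 3 to compound 4 (0.13 log units; within the scatter), expected to stay within the scatter. Compound 4 is therefore estimated at 150 nM, with a range from 60 nM to 400 nM.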

Compound 4, half-maximal effective concentration: 805 nM
For compound 4 the middle estimate is 5.4-fold (0.73 log units) below the measured one; measured number outside the range, above it.
By their numbers in this assay, from the lowest: compounds 1, 2 and 3 (each within the scatter of the next, the first and the last beyond it); then compound 4.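

At the oxygen on the aromatic ring, the exchanges among the three alkyl groups stay small, but benzyl breaks that picture: in this assay it gives a 7.3-fold higher number from compound 3 to compound 4 (0.86 log units; beyond the scatter) and, against the other two groups, a 12-fold higher number from compound 2 to compound 4 (1.06 log units; beyond the scatter) and a 16-fold higher number from compound 1 to compound 4 (1.21 log units; beyond the scatter). All three new steps lie beyond the scatter and each is larger than any step among compound 1, compound 2 and compound 3, so this position accepts exchange among these chains, with or without fluorine, yet responds strongly to the one group shown that carries a six-membered aromatic ring of carbon only, a reading that rests on the single example of compound 4. No measurement at hand accounts for this rise.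

The compounds shown do not separate the aromatic ring itself from the overall size of the group, and a cyclohexylmethyl group at the same oxygen would bear directly on that. Going by these compounds, how far the rise depends on the ring's make-up or its distance from the oxygen also stays open, and a pyridylmethyl, a fluorobenzyl or a 2-phenylethyl group would address it.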